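The compounds below may be only part of what the source reports. "The series", "measured", "known", "first", "only" and "open" are said of these compounds alone.

Compound 1 `CCN(CCCCn1sc2cc(OC)c(OC)cc2c1=O)Cc1ccccc1OC`: 9600 nM
Compound 2 `CCN(CCCCn1sc2cc(OC)c(OC)cc2c1=O)Cc1ccccc1N(C)C`: 9900 nM
Compound 3 `CCN(CCCCCCn1sc2cc(OC)c(OC)cc2c1=O)Cc1ccccc1OC`: 7900 nM

All three were tested in an assay on isolated protein for inhibition of Amine oxidase [flavin-containing] A (Homo sapiens), read by fluorescence, with a stated time of 30 min; on this read-out lower numbers stand for stronger inhibition and higher numbers for weaker inhibition. Compound 1 and compound 2 share one core and differ in a single place: dimethylamino in place of methoxy on an aromatic carbon. That change gave a 1.0-fold higher number from compound 1 to compound 2 (0.01 log units; within the scatter). Compound 3 carries a different core; how the two cores differ is not broken down here. Compound 4 `CCN(CCCCCCn1sc2cc(OC)c(OC)cc2c1=O)Cc1ccccc1N(C)C` has not yet been measured. It stands to compound 3 exactly as compound 2 stands to compound 1: dimethylamino in place of methoxy on an aromatic carbon. Because the same change at the same place gave a 1.0-fold higher number from compound 1 to compound 2 (0.01 log units; within the scatter), a step of similar size is expected here, resting on compound 3 giving 7900 nM in this assay. The expected step is a 1.0-fold higher number from compound 3 to compound 4 (0.01 log units; within the scatter). Compound 4 is therefore estimated at 8000 nM, with a likely range from 4000 nM to 16000 nM.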

Compound 4, half-maximal inhibitory concentration: 3400 nM
For compound 4 the middle estimate is 2.4-fold (0.37 log units) above the measured one; measured number below the stated range.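

In this assay, dimethylamino in place of methoxy gave a 2.3-fold lower number from compound 3 to compound 4 (0.37 log units; beyond the scatter), a modest gain on the core of compound 3, whereas the same change on the core of compound 1 made no readable difference. Even so, the two steps cannot be told apart, so these pairs do not show that the change behaves differently on the two cores: the same change on two cores in this assay, a 1.0-fold higher number (0.01 log units; within the scatter) from compound 1 to compound 2 and a 2.3-fold lower number (0.37 log units; beyond the scatter) from compound 3 to compound 4, 2.4-fold (0.38 log units) apart, within the scatter of two such steps Two pairs also cannot show how the change would behave on any further core.

On these data alone, it remains open how other groups would fare in the same place, such as a chlorine atom, a primary amine or a morpholine ring. A longer chain than the one in compound 3 also remains untested among the compounds shown here.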